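Trifluoromethyl in Place of Dimethylamino on the Aryl Hydrazone

A few compounds are considered here, and "the series" means these few. Any claim that something is new, unique, unknown or untested is made for them only; others in the source may bear on it.

Three compounds that share one core have been measured in an assay on CHO-K1 cells for displacement of a labelled ligand from adenosine receptor A1 (Homo sapiens), read by scintillation counting, with a stated time of 60 min; a lower number here means a stronger inhibitor, a higher number a weaker inhibitor:

Compound 1, `Nc1nc(N/N=C/c2cncs2)nc2c1ncn2[C@@H]1O[C@H](CO)[C@@H](O)[C@H]1O`, gives 22 nM.
Compound 2, `Nc1nc(N/N=C/c2ccc(N3CCCC3)cc2)nc2c1ncn2[C@@H]1O[C@H](CO)[C@@H](O)[C@H]1O`, gives 5.1 nM.
Compound 3, `CN(C)c1ccc(/C=N/Nc2nc(N)c3ncn([C@@H]4O[C@H](CO)[C@@H](O)[C@H]4O)c3n2)cc1`, gives > 10000 nM.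

The reading for compound 3 is a limit of the assay, not a number: it sits at the limit of > 10000 nM in this assay, at which 1 of the 3 values shown sits. So compound 3 stands apart from the other two, which both give real numbers. The step of an at least 1900-fold higher number from compound 2 to compound 3 (3.29 log units; beyond the scatter) is large, and so is an at least 450-fold higher number from compound 1 to compound 3 (2.65 log units; beyond the scatter), whereas a 4.3-fold lower number from compound 1 to compound 2 (0.63 log units; beyond the scatter) is modest.

Compound 4, `Nc1nc(N/N=C/c2ccc(C(F)(F)F)cc2)nc2c1ncn2[C@@H]1O[C@H](CO)[C@@H](O)[C@H]1O`, has not yet been measured. It differs from compound 3 by trifluoromethyl in place of dimethylamino on an aromatic carbon. Among the measured compounds shown here, no measured step replaces a dimethylamino with a trifluoromethyl, so the two large steps into compound 3 give only indirect guidance. What the numbers do show is that the two compounds without a dimethylamino on the ring, compound 1 and compound 2, both give measurable values, while compound 3 alone falls at the limit. On that basis compound 4 is expected to return a measurable number rather than a limit, which would mean an expected step of an at least 33-fold lower number from compound 3 to compound 4 (1.52 log units; beyond the scatter) in this assay. The estimate for compound 4 is 300 nM, with a range from 20 nM to 8000 nM.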

Compound 4, inhibition constant: 37 nM
Compound 4: the middle estimate sits 8.1-fold (0.91 log units) above what was measured, within the range that was stated.
By their numbers in this assay, from the lowest: compound 2; then compounds 1 and 4 (each within the scatter of the next). At a limit, above all of these: compound 3.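

Trifluoromethyl is the first group on this aromatic carbon to stand in for dimethylamino, and in this assay the change gives an at least 270-fold lower number from compound 3 to compound 4 (2.43 log units; beyond the scatter), so of the three groups seen on this ring, only dimethylamino ends at a limit. Going by these compounds, compound 3 is still a limit of the assay and not a number, so the true size of that step stays unknown: the limit of > 10000 nM in this assay, at which 1 of the 4 values shown sits. Among the measured numbers, the group on the ring still counts, as trifluoromethyl in place of pyrrolidin-1-yl gives a 7.3-fold higher number from compound 2 to compound 4 (0.86 log units; beyond the scatter), while the change between the two whole ring groups gives a 1.7-fold higher number from compound 1 to compound 4 (0.23 log units; within the scatter), so compound 1 and compound 4 cannot be told apart here.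

On these data alone, it remains open whether a diethylamino or a piperidin-1-yl on this carbon would end at a limit like dimethylamino or give a low number like pyrrolidin-1-yl, which would show whether the sharp contrast between compound 2 and compound 3 belongs to dimethylamino alone. As far as these compounds go, it is equally open whether a methoxy, a chlorine or a nitrile would give numbers close to that of trifluoromethyl, and a single comparison cannot settle this.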